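The source may hold more compounds than are shown below. What is called first, only, known or untested is meant among the compounds shown, and "the series" means these compounds.

Compound 1 `COc1ccc(N/N=C2\C(=O)N(Cc3cn(O[C@@H]4O[C@H](CO)[C@@H](O)[C@H](O)[C@H]4O)nn3)c3ccccc32)cc1`, half-maximal cytotoxic concentration 79600 nM.
Compound 2 `O=C1/C(=N\Nc2ccccc2)c2ccccc2N1Cc1cn(O[C@@H]2O[C@H](CO)[C@H](O)[C@H](O)[C@H]2O)nn1`, half-maximal cytotoxic concentration 83400 nM.

Both numbers come from an ADME assay on Vero cells (Chlorocebus sabaeus) for cytotoxicity, read by fluorescence and resazurin assay, with a stated time of 3 days; a higher number here means that more compound is tolerated, a lower number that less compound is tolerated. Compound 2 and compound 1 stand so close together that the gap between them lies within the scatter of this assay, and nothing can be read from their order; both are tolerated at a high concentration. The account here follows the step from compound 2 to compound 3 `COc1ccc(N/N=C2\C(=O)N(Cc3cn(O[C@@H]4O[C@H](CO)[C@H](O)[C@H](O)[C@H]4O)nn3)c3ccccc32)cc1`, which has not yet been measured in this assay. The structural change is methoxy in place of hydrogen on an aromatic carbon. Among the compounds with values here, no measured pair in this set shows this same change, so the expectation rests only on the two numbers already in hand, which do not separate from each other. The step is therefore expected to be no larger than the scatter, in no particular direction: a 1.0-fold lower number from compound 2 to compound 3 (0.02 log units; within the scatter) is the expected change in this assay. On that basis compound 3 is estimated at 80000 nM in this assay, with a likely range from 45000 nM to 140000 nM.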

Compound 3, half-maximal cytotoxic concentration: 76200 nM
For compound 3 the middle estimate is 1.0-fold (0.02 log units) above the measured one, within the range that was stated.
By their numbers in this assay, from the lowest: compounds 3, 1 and 2 (each within the scatter of the next).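

In this assay, methoxy in place of hydrogen on an aromatic carbon, para to a large group, turning phenyl into 4-methoxyphenyl, gives a 1.1-fold lower number from compound 2 to compound 3 (0.04 log units; within the scatter), so this position takes the methoxy group without a step that stands out from the scatter. Compound 3 also adds a comparison at a stereocentre on a saturated ring carbon, drawn S in compound 1 and R in compound 3, and this gives a 1.0-fold lower number from compound 1 to compound 3 (0.02 log units; within the scatter), again with no separation. This second step can be read as concerning that stereocentre alone: the fact that compounds 1 and 3 differ only in the configuration as drawn

Going by these compounds, only hydrogen and methoxy appear at the aromatic position in these compounds, so it remains open whether an amine, a carboxylic acid or a longer alkoxy chain there would leave the number in the same place. It is also open whether changing any of the other stereocentres would matter, as the compounds shown vary only the one.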